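A Halogen Swap on the Aryl Ring of a Shared Core

A few compounds are considered here, and "the series" means these few. Any claim that something is new, unique, unknown or untested is made for them only; others in the source may bear on it.

Compound 3 `CCNC(=O)c1cc(Oc2ccc(NC(=O)c3cc4cccnc4n(-c4ccc(Cl)cc4)c3=O)cc2)ccn1` enters this account without a number of its own: in a functional assay on U-87MG ATCC cells for antiproliferative activity against U-87 MG (Homo sapiens), read by MTT assay, with a stated time of 72 h (on this read-out lower numbers stand for stronger inhibition and higher numbers for weaker inhibition), the result for compound 3 is "not determined" (no result reported). It is not alone in that, since compound 1 `CNC(=O)c1cc(Oc2ccc(NC(=O)c3cc4cccnc4n(-c4ccc(Br)cc4F)c3=O)cc2)ccn1` also returns "not determined" (no result reported) in this assay. The one firm point in the series is compound 2 `CCNC(=O)c1cc(Oc2ccc(NC(=O)c3cc4cccnc4n(-c4ccc(F)cc4)c3=O)cc2)ccn1`, which in this assay gives 1130 nM. For the measured compounds named here, compound 2 shares the ethyl amide and the rest of the core with compound 3, and differs from it only in the halogen carried on the aryl ring attached to the aromatic nitrogen; no step between the two is set out, so their values can only be placed side by side, and one of the two is missing.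

Compound 4 `CCNC(=O)c1cc(Oc2ccc(NC(=O)c3cc4cccnc4n(-c4ccc(Br)cc4F)c3=O)cc2)ccn1` is the untested member. Its change from compound 3 is 4-bromo-2-fluorophenyl in place of 4-chlorophenyl on an aromatic nitrogen, in words 4-bromo-2-fluorophenyl in place of 4-chlorophenyl on an aromatic nitrogen. With no measured step of this kind in hand, the expectation for this assay is a shift no larger than the usual scatter, in either direction. Taking compound 2 as the nearest anchor, compound 4 is expected to give about 1000 nM, within a range of 300 nM to 3500 nM.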

Compound 4, half-maximal inhibitory concentration: 10300 nM
Beside the measured number, compound 4's estimate is 10-fold (1.01 log units) below it; measured number above the stated range.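

The aryl group on the aromatic nitrogen proves not to be a neutral place on this core. With the ethyl amide and the rest of the shared core held constant, 4-bromo-2-fluorophenyl in place of 4-fluorophenyl gives a 9.1-fold higher number from compound 2 to compound 4 (0.96 log units; beyond the scatter) in this assay and so moves the series toward weaker inhibition by more than the usual scatter. For the compounds shown here, this is the first readable step, and it shows that two halogen-bearing phenyl groups on the same nitrogen are not interchangeable here, although the data offer no measurement that would account for the loss.

The step from compound 3 to compound 4 cannot be read, and neither can any comparison involving compound 1, as neither compound has a number in this set. Because compound 4 carries both a bromine and a second fluorine relative to compound 2, the compounds shown leave open which of the two goes with the weaker result, a question that 4-bromophenyl or 2-fluorophenyl on the same nitrogen would address.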